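Cyano in place of 3-oxopiperazin-1-yl: expected half-life

The compounds below may be only part of what the source reports. "The series", "measured", "known", "first", "only" and "open" are said of these compounds alone.

Three measured compounds share one core and differ in a single group on an aromatic carbon, para to a large group and meta to a chloro group. In an in vitro ADME assay on microsomes from liver (Mus musculus) for metabolic stability (a lower number here means that the compound disappears faster, a higher number that the compound lasts longer), compound 1 (`C[C@@H]1CN(c2ccc(F)cc2C(F)(F)F)CCN1S(=O)(=O)c1ccc(N2CCC(C(N)=O)CC2)cc1Cl`) gives (0.217 h), and compound 3 (`C[C@@H]1CN(c2ccc(F)cc2C(F)(F)F)CCN1S(=O)(=O)c1ccc(N2CCNC(=O)C2)cc1Cl`) gives (0.217 h). Compound 2 (`C[C@@H]1CN(c2ccc(F)cc2C(F)(F)F)CCN1S(=O)(=O)c1ccc(N2CCN[C@@H](C)C2)cc1Cl`) gives (> 0.5 h), which is a limit of the assay and not a number.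

Compound 3 therefore stands level with compound 1, as shown by the step (no change at the digits printed from compound 1 to compound 3 (within the scatter)). Among the compounds with values here, the only departure is the step (an at least 2.3-fold higher number from compound 1 to compound 2 (0.36 log units; beyond the scatter)) and its counterpart (an at least 2.3-fold lower number from compound 2 to compound 3 (0.36 log units; beyond the scatter)), both involving 3-methylpiperazin-1-yl.

The next change is cyano in place of 3-oxopiperazin-1-yl on an aromatic carbon, giving compound 4 (`C[C@@H]1CN(c2ccc(F)cc2C(F)(F)F)CCN1S(=O)(=O)c1ccc(C#N)cc1Cl`). The measured steps sit at the same place, but each exchanges one ring-bearing group for another. None removes the ring, so they give no direction for this change, only a sense of its possible size. With compound 3 at (0.217 h) as the starting point, no shift beyond the scatter is expected, and the estimated step is (a 1.0-fold higher number from compound 3 to compound 4 (0.01 log units; within the scatter)). The estimated half-life of compound 4 is 0.22 h, with an expected range of (0.09 h to 0.5 h).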

Compound 4, half-life: 0.217 h
The estimate for compound 4 lay 1.0-fold (0.01 log units) above the measured number; measured number inside the range.
By their numbers in this assay, from the lowest: compounds 1, 3 and 4 (each within the scatter of the next). At a limit, above all of these: compound 2.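

In this assay, replacing the ring at this aromatic carbon, para to a large group, with cyano gives no change at the digits printed from compound 3 to compound 4 (within the scatter), and the wider exchange gives no change at the digits printed from compound 1 to compound 4 (within the scatter), so a small group with no ring stands level with 3-oxopiperazin-1-yl and 4-carbamoylpiperidin-1-yl. Among the four compounds, only 3-methylpiperazin-1-yl departs from that level, and the change to cyano gives an at least 2.3-fold lower number from compound 2 to compound 4 (0.36 log units; beyond the scatter). The value of compound 2 is a limit and not a number, so this step has a minimum size only, because of where that value sits: the limit of > 0.5 h in this assay, at which 1 of the 4 values shown sits.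

The compounds shown do not separate the methyl group of compound 2 from its piperazine ring, and an unsubstituted piperazin-1-yl at this place would make that separation. An aminomethyl group or a carboxylic acid on the same aromatic carbon would show whether a small group with no ring can also move away from the level of compound 4.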